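The compounds below may be only part of what the source reports. "The series", "measured", "known", "first", "only" and "open" are said of these compounds alone.

Three compounds have been measured in a functional assay on T47D cells (Homo sapiens) for cytotoxicity, read by CCK-8 assay; a lower number here means a stronger inhibitor, a higher number a weaker inhibitor:

Compound 1, `Oc1ccc(-c2cc(-c3ccsc3)cc(-c3cccc(O)c3)n2)cc1`: 760 nM
Compound 2, `Oc1ccc(-c2cc(-c3ccco3)cc(-c3cccc(O)c3)n2)cc1`: 1280 nM
Compound 3, `Oc1cccc(-c2cc(-c3ccoc3)cc(-c3cccc(O)c3)n2)c1`: 2590 nM

Compound 3 stands with the highest of the three numbers; the gap to compound 2 lies beyond the scatter, and the gap to compound 1 is wider still. Among the measured compounds shown here, the only single-point step among the measured compounds, a 1.7-fold higher number from compound 1 to compound 2 (0.23 log units; within the scatter), concerns the five-membered ring and not the hydroxyphenyl groups, so it bears on the next step only indirectly.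

Compound 4, `Oc1ccc(-c2cc(-c3ccoc3)cc(-c3cccc(O)c3)n2)cc1`, differs from compound 3 in one place: 4-hydroxyphenyl in place of 3-hydroxyphenyl on an aromatic carbon. For the measured compounds named here, no measured pair isolates this exchange. Compound 2, which carries a 4-hydroxyphenyl group together with a 3-hydroxyphenyl group, gives 1280 nM, while compound 3, with two 3-hydroxyphenyl groups, gives 2590 nM; what the two values show is a lower number for the compound with one of each. On that basis a modest downward step is expected, a 1.7-fold lower number from compound 3 to compound 4 (0.24 log units; within the scatter), close to the edge of the scatter. For compound 4 the estimate in this assay is 1500 nM, with a likely range from 650 nM to 3500 nM.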

Compound 4, half-maximal inhibitory concentration: 2610 nM
The estimate for compound 4 lay 1.7-fold (0.24 log units) below the measured number, and the stated range covers the measured number.
By their numbers in this assay, from the lowest: compounds 1 and 2 (each within the scatter of the next); then compounds 3 and 4 (each within the scatter of the next).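

In this assay, 4-hydroxyphenyl in place of 3-hydroxyphenyl at this place next to the ring nitrogen gives a 1.0-fold higher number from compound 3 to compound 4 (0.00 log units; within the scatter) and so shows no measurable change when furan-3-yl is present. The five-membered ring can now be read directly on the same background: furan-3-yl in place of furan-2-yl gives a 2.0-fold higher number from compound 2 to compound 4 (0.31 log units; beyond the scatter) and furan-3-yl in place of thiophen-3-yl gives a 3.4-fold higher number from compound 1 to compound 4 (0.54 log units; beyond the scatter), both modest steps, so among these four compounds the differences beyond the scatter follow the five-membered ring and not the hydroxyphenyl exchange. No measurement offered here explains these steps.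

From the compounds shown here alone, whether the hydroxyphenyl exchange is equally silent with furan-2-yl or thiophen-3-yl present remains open. Also open, going by these compounds, is how this assay would respond to an amine or a carboxylic acid in place of the hydroxyl group on this ring.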